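Ester variation on the shared core: cytotoxicity working notes

The compounds below may be only part of what the source reports. "The series", "measured", "known", "first", "only" and "open" are said of these compounds alone.

Compound 1 `Cc1cccc(C(=O)OC2CCC(CN3CCN(c4cc(=O)c5cc(C(F)(F)F)cc([N+](=O)[O-])c5s4)CC3)CC2)c1` stands only at a limit in an ADME assay on Vero cells (Chlorocebus sabaeus) for cytotoxicity, read by MTT assay, with a stated time of 48 h; on this read-out higher numbers stand for weaker inhibition and lower numbers for stronger inhibition; in this assay compound 1 gives > 64 ug/mL, a limit of the assay and not a number. Compound 2 `CC(C)C(=O)OC1CCC(CN2CCN(c3cc(=O)c4cc(C(F)(F)F)cc([N+](=O)[O-])c4s3)CC2)CC1` likewise returns a limit in this assay, > 64 ug/mL. The step that the two limits leave unreadable from compound 1 to compound 2 cannot be read, since both values sit at the limit of > 64 ug/mL in this assay, at which 2 of the 2 values shown sit. Compound 3 `O=C(OC1CCC(CN2CCN(c3cc(=O)c4cc(C(F)(F)F)cc([N+](=O)[O-])c4s3)CC2)CC1)c1ccncc1` differs from compound 1 by pyridin-4-yl in place of 3-methylphenyl on a carbonyl carbon. No readable measured step bears on this change; the two limits are all that is shown. The step that the limit leaves unreadable from compound 1 to compound 3 is expected to remain within the unreadable range. Compound 3 is therefore estimated at 90 ug/mL, between 45 ug/mL and 200 ug/mL, most probably reported once more as a limit.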

Compound 3, half-maximal inhibitory concentration: > 64 ug/mL
Compound 3: no number, only a limit; the forecaster's own chance of this, stated with the estimate: 85%; the middle value does not contradict the limit.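

In this assay compound 3 gives > 64 ug/mL as a limit of the assay and not a number. Among these compounds, no step among compound 1, compound 2 and compound 3 can be read: the limit of > 64 ug/mL in this assay, at which 3 of the 3 values shown sit. On these data alone, whether these ester groups differ in cytotoxicity stays open.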